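The source may report more compounds than this note shows. Statements on the series, on what has been measured and on what is new or still open speak of the compounds shown alone.

Of the compounds shown here, three that share one core have been measured so far. Compound 1 `CCC/N=C(\S)OC[C@H]1OC(n2cnc3c(NC4CCOC4)ncnc32)[C@H](O)[C@@H]1O` gives 50 nM in an assay on DDT1 cells (Cricetulus griseus) for binding affinity to adenosine receptor A1 (Homo sapiens), read by radioligand binding; a higher number here means a weaker inhibitor, a lower number a stronger inhibitor. Compound 2 `O[C@@H]1[C@@H](CO/C(S)=N/C2CCCCC2)OC(n2cnc3c(NC4CCOC4)ncnc32)[C@@H]1O` gives 253 nM in this assay, and compound 3 `C=CC/N=C(\S)OC[C@H]1OC(n2cnc3c(NC4CCOC4)ncnc32)[C@H](O)[C@@H]1O` gives 35 nM. Compound 3 has the lowest number of the three, with compound 1 close by: the change a 1.4-fold lower number from compound 1 to compound 3 (0.15 log units; within the scatter) stays within the scatter, whereas a 7.2-fold lower number from compound 2 to compound 3 (0.86 log units; beyond the scatter) lies beyond it, as does a 5.1-fold higher number from compound 1 to compound 2 (0.70 log units; beyond the scatter).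

Compound 4 `CN(C)C(=O)OC[C@H]1OC(n2cnc3c(NC4CCOC4)ncnc32)[C@H](O)[C@@H]1O` differs from compound 3 in the group on the oxygen on a saturated carbon: a group of 5 heavy atoms (3 carbon, 1 nitrogen, 1 oxygen; no ring) in place of a group of 6 heavy atoms (4 carbon, 1 nitrogen, 1 sulfur; no ring), on an oxygen on a saturated carbon. For the measured compounds named here, none of the measured steps alters this part of the structure; all three steps exchange only the substituent on the double-bonded nitrogen, and the largest of them, a 7.2-fold lower number from compound 2 to compound 3 (0.86 log units; beyond the scatter), remains modest. Going by the values given here, the new change is of a different kind, so no measured step bears on it directly, and the direction cannot be read from the data with confidence. Compound 4 is therefore expected to show a modest step, a 3.4-fold higher number from compound 3 to compound 4 (0.54 log units; beyond the scatter), towards a higher number. The estimate for compound 4 in this assay is 120 nM, within a range from 30 nM to 500 nM.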

Compound 4, inhibition constant: 238 nM
Compound 4: the middle estimate sits 2.0-fold (0.30 log units) below what was measured, within the range that was stated.
By their numbers in this assay, from the lowest: compounds 3 and 1 (each within the scatter of the next); then compounds 4 and 2 (each within the scatter of the next).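

For the compounds shown here, the group on the oxygen on a saturated carbon turns out to matter to binding: dimethylcarbamoyl gives a 6.8-fold higher number from compound 3 to compound 4 (0.83 log units; beyond the scatter) and a 4.8-fold higher number from compound 1 to compound 4 (0.68 log units; beyond the scatter), both beyond the scatter, whereas the earlier steps touched only the substituent on the double-bonded nitrogen. With a 1.1-fold lower number from compound 2 to compound 4 (0.03 log units; within the scatter), within the scatter, dimethylcarbamoyl places compound 4 level with compound 2 and apart from compound 1 and compound 3. Nothing available explains these differences.

The change swaps the sulfur for an oxygen and also alters the substituents on the nitrogen, and the compounds shown do not separate the two. On these data alone, whether a propylcarbamoyl or allylcarbamoyl group on this oxygen would stand with compound 3 or with compound 4 remains open.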